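The source may hold more compounds than are shown below. What is called first, only, known or untested is meant among the compounds shown, and "the series" means these compounds.

In a functional assay on MCF7 cells (Homo sapiens) for cytotoxicity, read by MTT assay, with a stated time of 24 h (a lower number here means a stronger inhibitor, a higher number a weaker inhibitor), compound 1 `Cc1cc(O)c(C(=O)/C=C/c2ccc(Br)cc2)c(-c2ccc(OCc3ccccc3)cc2)c1C(=O)/C=C/c1ccc(Br)cc1` gives 30000 nM. Compound 2 `Cc1cc(O)c(C(=O)/C=C/c2ccc(OCc3ccccc3)cc2)c(-c2ccccc2)c1C(=O)/C=C/c1ccc(OCc2ccccc2)cc1` gives 10000 nM, and compound 3 `Cc1cc(O)c(C(=O)/C=C/c2ccc(OCc3ccccc3)cc2)c(-c2ccc(OCc3ccccc3)cc2)c1C(=O)/C=C/c1ccc(OCc2ccccc2)cc1` gives 26000 nM. Compound 1 and compound 3 lie within the scatter of each other; how their cores differ is not broken down here. From compound 3 to compound 2 the change is hydrogen in place of benzyloxy on an aromatic carbon, and the step is a 2.6-fold lower number from compound 3 to compound 2 (0.41 log units; beyond the scatter).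

Compound 4 `Cc1cc(O)c(C(=O)/C=C/c2ccc(Br)cc2)c(-c2ccccc2)c1C(=O)/C=C/c1ccc(Br)cc1` has not been measured in this assay. It differs from compound 1 by hydrogen in place of benzyloxy on an aromatic carbon, the same change at the same place as from compound 3 to compound 2. Going by the values given here, for compound 4 the expected step is a 2.5-fold lower number from compound 1 to compound 4 (0.40 log units; beyond the scatter), resting on a 2.6-fold lower number from compound 3 to compound 2 (0.41 log units; beyond the scatter) as the only measured instance of this change, so the expectation carries little weight. The estimate for compound 4 in this assay is 12000 nM, expected to fall between 5000 nM and 30000 nM.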

Compound 4, half-maximal inhibitory concentration: 10000 nM
Beside the measured number, compound 4's estimate is 1.2-fold (0.08 log units) above it; the range from low to high includes it.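

In this assay, hydrogen in place of benzyloxy on an aromatic carbon gives a 3.0-fold lower number from compound 1 to compound 4 (0.48 log units; beyond the scatter). The change carries from one core to the other with a similar step: the same change on two cores in this assay, a 2.6-fold lower number (0.41 log units; beyond the scatter) from compound 3 to compound 2 and a 3.0-fold lower number (0.48 log units; beyond the scatter) from compound 1 to compound 4, 1.2-fold (0.06 log units) apart, within the scatter of two such steps This shows agreement between these two pairs only; it does not show that the step would hold on other cores, nor does it explain why the number falls.

Among the compounds shown, only benzyloxy and hydrogen stand at this place. As far as these compounds go, whether methoxy, a hydroxyl or an amine there would give a number closer to that of compound 4 or to that of compound 1 remains open.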